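This account rests on a few compounds, and the source may have more. Where it says the series, first, only, none or still open, it means among the compounds named here.

Measured so far:
Compound 1, `CCCCCNC(=O)[C@H]1O[C@@H](n2cnc3c(N)ncnc32)[C@H](O)[C@@H]1O`, in an assay on cell membranes for binding affinity to 2-oxoglutarate receptor 1 (Rattus norvegicus), read by radioligand binding (on this read-out lower numbers stand for stronger inhibition and higher numbers for weaker inhibition), compound 1 gives 12 nM.
Compound 2, `CCCCCCCNC(=O)[C@H]1OC(n2cnc3c(N)ncnc32)[C@H](O)[C@@H]1O`, in this assay compound 2 gives 20 nM.

Compound 2 has the higher of the two numbers, but its neighbour compound 1 sits within the usual scatter of it, so the two cannot be told apart on this read-out. Compound 3, `CCCCCCCCCCCCNC(=O)[C@H]1OC(n2cnc3c(N)ncnc32)[C@H](O)[C@@H]1O`, has not been measured. It differs from compound 2 by pentyl in place of hydrogen on a saturated chain carbon, seven bonds along the chain from an amide-type nitrogen. Going by the values given here, no measured pair in this set shows the effect of such a change, so there is no step to lean on; the only guidance is that compound 1 and compound 2, which differ in chain length, give values within the scatter of each other. A longer chain still is expected to cost some affinity, a step from compound 2 to compound 3 of roughly a 2.0-fold higher number from compound 2 to compound 3 (0.30 log units; within the scatter), around the edge of the scatter. Compound 3 is therefore estimated at 40 nM, within 12 nM to 150 nM.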

Compound 3, inhibition constant: 163 nM
For compound 3 the middle estimate is 4.1-fold (0.61 log units) below the measured one; the measured number lies above the stated range.
By their numbers in this assay, from the lowest: compounds 1 and 2 (each within the scatter of the next); then compound 3.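

Putting pentyl in place of hydrogen on a saturated chain carbon, seven bonds along the chain from an amide-type nitrogen, gives an 8.2-fold higher number from compound 2 to compound 3 (0.91 log units; beyond the scatter) in this assay. Going by these compounds alone, this is the first step in the set that can be read beyond the scatter, and it shows that this place on the chain is not indifferent to added carbon: the longer chain of compound 3 binds more weakly than that of compound 2. The data shown offer no measurement that accounts for this loss.

The compounds shown leave open how ethyl or propyl in place of the same hydrogen would read, and so whether the number climbs steadily with each added carbon or jumps at one length. They also leave open whether an amine or a carboxylic acid there would fare as pentyl does.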